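Weinreb Amide to Ethyl Ester on a Purine Nucleoside Scaffold

This account rests on a few compounds, and the source may have more. Where it says the series, first, only, none or still open, it means among the compounds named here.

Measured compounds:
Compound 1, `CCOC(=O)C[C@H]1[C@@H](O[Si](C)(C)C(C)(C)C)[C@H](n2cnc3c(NC(=O)Nc4ccccc4)ncnc32)O[C@@H]1COC(=O)NC` — 12.9 nM
Compound 2, `CNC(=O)NC[C@H]1O[C@@H](n2cnc3c(NC(=O)Nc4ccccc4)ncnc32)[C@H](O[Si](C)(C)C(C)(C)C)[C@@H]1CC(=O)N(C)OC` — 57.2 nM

In a functional assay on NCI-H23 cells (Homo sapiens) for antiproliferative activity (a higher number here means a weaker inhibitor of growth, a lower number a stronger inhibitor of growth), compound 1 gives 12.9 nM. In this assay compound 2 gives 57.2 nM, the higher of the two numbers; compound 1 and compound 2 differ at more than one place, so their two values alone show the gap between them.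

Compound 3, `CCOC(=O)C[C@H]1[C@@H](O[Si](C)(C)C(C)(C)C)[C@H](n2cnc3c(NC(=O)Nc4ccccc4)ncnc32)O[C@@H]1CNC(=O)NC`, has not yet been measured. It follows from compound 2 by a single change: ethoxy in place of methoxy(methyl)amino on a carbonyl carbon. Within the data shown here, compound 3 shares its ethoxycarbonyl with compound 1 but differs from compound 1 at another position, so no single measured step describes this change.

Compound 3 is expected to give a lower number than compound 2 in this assay, a step of a 2.3-fold lower number from compound 2 to compound 3 (0.36 log units; beyond the scatter), beyond the scatter but modest. The estimate for compound 3 is 25 nM, with a range from 10 nM to 70 nM.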

Compound 3, concentration for 50% growth inhibition: 33.3 nM
Beside the measured number, compound 3's estimate is 1.3-fold (0.12 log units) below it; the measured number falls inside the stated range.
By their numbers in this assay, from the lowest: compound 1; then compounds 3 and 2 (each within the scatter of the next).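

In this assay, ethoxy in place of methoxy(methyl)amino on a carbonyl carbon gives a 1.7-fold lower number from compound 2 to compound 3 (0.23 log units; within the scatter), so at this position the ester and the Weinreb amide cannot be told apart. The other place carries the larger step: (methylcarbamoyl)amino in place of (methylcarbamoyl)oxy on a saturated chain carbon bound to a saturated ring carbon gives a 2.6-fold higher number from compound 1 to compound 3 (0.41 log units; beyond the scatter), the only one of the two single changes that is beyond the scatter. Nothing available explains either step.

On these data alone, it remains open whether a carboxylic acid, a primary amide or a longer alkyl ester on the same carbonyl carbon would stay within the scatter of these values. Also open, as far as these compounds go, is whether the two changes act independently, which the pairing of methoxy(methyl)carbamoyl with (methylcarbamoyl)oxy would test.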